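Sulfonamide for sulfone on a weak cell-growth inhibitor

The source may hold more compounds than are shown below. What is called first, only, known or untested is meant among the compounds shown, and "the series" means these compounds.

Measured compounds:
- compound 1, `Cn1c(=O)c(S(=O)(=O)Cc2ccc(F)cc2)cc2cnc(Nc3ccc4[nH]ccc4c3)nc21`: 30000 nM
- compound 2, `Cn1ccc2cc(Nc3ncc4cc(S(=O)(=O)c5ccc(F)cc5F)c(=O)n(C)c4n3)ccc21`: 750 nM
- compound 3, `CN1CCN(c2ccc(Nc3ncc4cc(S(=O)(=O)c5ccc(F)cc5F)c(=O)n(C)c4n3)cc2)CC1`: 5000 nM

In a functional assay on DU-145 cells (Homo sapiens) for inhibition, read by trypan blue exclusion, with a stated time of 72 h (a higher number here means a weaker inhibitor, a lower number a stronger inhibitor), compound 1 stands at the highest number of the three, beyond the scatter from both compound 3 and compound 2, so it is the weakest inhibitor here. Compounds 2 and 3 differ from compound 1 in more than one place, so no single step can be read from them.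

Compound 4, `Cn1c(=O)c(S(=O)(=O)Nc2ccc(F)cc2)cc2cnc(Nc3ccc4[nH]ccc4c3)nc21`, is not yet measured. It differs from compound 1 in one place: (4-fluorophenyl)amino in place of 4-fluorobenzyl on a sulfonyl sulfur.

Among the measured compounds shown here, with no matching step in the data, a modest move in either direction, or none beyond the scatter, is expected for a 2.0-fold lower number from compound 1 to compound 4 (0.30 log units; within the scatter). The estimate for compound 4 in this assay is 15000 nM, between 3000 nM and 60000 nM.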

Compound 4, half-maximal inhibitory concentration: 5000 nM
Compound 4: the middle estimate sits 3.0-fold (0.48 log units) above what was measured; the measured number falls inside the stated range.
By their numbers in this assay, from the lowest: compound 2; then compounds 3 and 4 (each within the scatter of the next); then compound 1.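

In this assay, among the compounds shown here, replacing 4-fluorobenzyl with (4-fluorophenyl)amino on the sulfonyl sulfur gives a 6.0-fold lower number from compound 1 to compound 4 (0.78 log units; beyond the scatter), the first single change at this position that can be read. The number at this position therefore responds to this swap, which keeps the count of heavy atoms and the single aromatic ring but adds a hydrogen-bond donor. Nothing measured here accounts for the change.

A (4-fluorophenyl)(methyl)amino group on the same sulfur would test whether the amine hydrogen matters. A plain amine or a longer chain there remains an open comparison.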